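Replacing diisopropylamino on the shared core

The source may report more compounds than this note shows. Statements on the series, on what has been measured and on what is new or still open speak of the compounds shown alone.

In a functional assay on MCF7 cells (Homo sapiens) for antiproliferative activity, read by MTT assay, with a stated time of 48 h (on this read-out lower numbers stand for stronger inhibition and higher numbers for weaker inhibition), compound 1 `CC(C)=CCC[C@]1(C)/C=C/[C@@H](OC(=O)C=C(C)C)[C@](C)(O)/C=C/C(=O)/C(C=O)=C\C1` gives 12600 nM, compound 2 `CC(C)=CCC[C@]1(C)/C=C/[C@@H](OC(=O)C=C(C)C)[C@](C)(O)/C=C/C(=O)/C(C(=O)O)=C\C1` gives 16100 nM and compound 3 `CC(C)=CCC[C@]1(C)/C=C/[C@@H](OC(=O)C=C(C)C)[C@](C)(O)/C=C/C(=O)/C(CN(C(C)C)C(C)C)=C\C1` gives 780 nM, the lowest number of the three. The measured steps are a 1.3-fold higher number from compound 1 to compound 2 (0.11 log units; within the scatter), a 16-fold lower number from compound 1 to compound 3 (1.21 log units; beyond the scatter) and a 21-fold lower number from compound 2 to compound 3 (1.31 log units; beyond the scatter). Compound 4 `CC(C)=CCC[C@]1(C)/C=C/[C@@H](OC(=O)C=C(C)C)[C@](C)(O)/C=C/C(=O)/C(COC(=O)c2ccc([N+](=O)[O-])cc2)=C\C1` differs from compound 3 as follows: ((4-nitrophenyl)carbonyl)oxy in place of diisopropylamino on a saturated chain carbon bound to a double-bonded ring carbon. It has ((4-nitrophenyl)carbonyl)oxy in place of diisopropylamino on a saturated chain carbon bound to a double-bonded ring carbon. For the measured compounds named here, no measured compound carries the entering group, so the evidence is indirect. Compound 4 lacks diisopropylamino, as do compound 1 and compound 2, and the large 16-fold lower number from compound 1 to compound 3 (1.21 log units; beyond the scatter) suggests a move towards higher numbers, probably only part of the way. The expected step in this assay is a 5.1-fold higher number from compound 3 to compound 4 (0.71 log units; beyond the scatter). The estimate for compound 4 is 4000 nM, within an expected range of 1200 nM to 14000 nM.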

Compound 4, half-maximal inhibitory concentration: 670 nM
Compound 4: middle estimate off by 6.0-fold (0.78 log units), on the high side; measured number below the stated range.
By their numbers in this assay, from the lowest: compounds 4 and 3 (each within the scatter of the next); then compounds 1 and 2 (each within the scatter of the next).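

In this assay the exchange gives a 1.2-fold lower number from compound 3 to compound 4 (0.07 log units; within the scatter) and so separates diisopropylamino from ((4-nitrophenyl)carbonyl)oxy by no measurable margin on this saturated chain carbon. The number reached by compound 3 therefore does not depend on diisopropylamino or on an amine at this place, since compound 4 carries an ester of 12 heavy atoms there, with one aromatic ring.

Open, on these data alone, is whether a hydroxymethyl group, a small acetate ester or a primary amine would hold the same number, and whether the nitro group of compound 4 contributes. Nothing available explains why the two groups match.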